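The compounds below may be only part of what the source reports. "The series", "measured", "known", "first", "only" and "open" are said of these compounds alone.

The series shares one core, seen in compound 1 `CCC(C(=O)N1CCN(c2cccc(OC)c2)CC1)N1C(=O)CCC1=O`, compound 2 `CCC(C(=O)N1CCN(c2ccccc2F)CC1)N1C(=O)CCC1=O` and compound 3 `CCC(C(=O)N1CCN(c2cccc(C(F)(F)F)c2)CC1)N1C(=O)CCC1=O`; only the aryl group on the amine nitrogen in the ring changes. In a functional assay on the whole organism (strain Swiss) with Mus musculus as the target, in the maximal electroshock model, with a stated time of 0.25 h, at a dose of 300 mg/kg by the intraperitoneal route (a higher number here means a stronger effect of the compound at the dose given, a lower number a weaker effect), compound 1 gives 25%, compound 2 gives 100% and compound 3 gives 75%. Compound 3 thus stands second of the three numbers: the climb from the methoxy analogue is a number 50 percentage points higher from compound 1 to compound 3 (beyond the scatter), while compound 2 sits higher still, the largest move being a number 75 percentage points higher from compound 1 to compound 2 (beyond the scatter).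

Compound 4 `CCC(C(=O)N1CCN(c2ccccc2)CC1)N1C(=O)CCC1=O` is not yet measured. Its change from compound 3 is hydrogen in place of trifluoromethyl on an aromatic carbon. Of the measured steps only one touches the same place, a number 50 percentage points higher from compound 1 to compound 3 (beyond the scatter), a large step in which trifluoromethyl replaced methoxy. Among the measured compounds shown here, no measured step removes a group to leave hydrogen, so the size of the present step has to be read from compound 1 at 25% and compound 3 at 75%; a hydrogen at that place is expected to land inside that span, nearer compound 3. The expected step is a number 20 percentage points lower from compound 3 to compound 4 (beyond the scatter), a drop of modest size. Compound 4 is therefore estimated at 55%, with a range from 25% to 90%.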

Compound 4, a percentage reported as activity, at one dose (the size of the read-out at that dose, not a potency): 75%
Compound 4: the middle estimate sits 20 percentage points below what was measured; the measured number falls inside the stated range.
By their numbers in this assay, from the lowest: compound 1; then compounds 3 and 4 (each within the scatter of the next); then compound 2.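

In this assay, the exchange of trifluoromethyl for hydrogen on the aromatic carbon gives no change at the digits printed from compound 3 to compound 4 (within the scatter) and so shows that, at the dose given, the read-out of compound 3 does not depend on the trifluoromethyl group being present at this place. With hydrogen now available as the reference, the earlier climb from the methoxy analogue can be read differently: a number 50 percentage points higher from compound 1 to compound 4 (beyond the scatter) marks compound 1 as the one that stands apart among the substituents at this place, while a number 25 percentage points lower from compound 2 to compound 4 (beyond the scatter) shows that the 2-fluorophenyl group of compound 2 gives a read-out that the plain hydrogen analogue does not reach. No measured information offered here accounts for either difference.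

The compounds shown leave open whether an amine, a carboxylic acid or a longer alkyl chain on this aromatic carbon would stay with compound 4 or fall toward compound 1. Also open, from the compounds shown here alone, is whether the tie seen in this assay between hydrogen and trifluoromethyl would hold at lower doses, since a read-out at one dose is not a potency.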